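This account rests on a few compounds, and the source may have more. Where it says the series, first, only, none or still open, it means among the compounds named here.

The measured compounds:
compound 1 `CC(=O)Nc1ccc(NC(=O)C(F)(F)C(F)(F)C(F)(F)C(F)(F)C(F)(F)C(F)(F)C(=O)NO)cc1`: in an ADME assay on isolated protein for inhibition of histone deacetylase 4 (Homo sapiens), read by fluorescence, with stated times of 30 min and 60 min (a lower number here means a stronger inhibitor, a higher number a weaker inhibitor), compound 1 gives > 50000 nM.
compound 2 `O=C(NO)C(F)(F)C(F)(F)C(F)(F)C(F)(F)C(F)(F)C(F)(F)C(=O)Nc1cccc(-c2cn(-c3ccccc3)nn2)c1`: in this assay compound 2 gives > 50000 nM.

The value of compound 1 is a limit of the assay, not a number. The value of compound 2 is likewise a limit. Compound 1 therefore stands at the limit of > 50000 nM in this assay, at which 2 of the 2 values shown sit, and nothing separates it from compound 2 on the numbers shown.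

Compound 3 `O=C(NO)C(F)(F)C(F)(F)C(F)(F)C(F)(F)C(F)(F)C(F)(F)C(=O)Nc1nc(-c2ccccc2)cs1` differs from compound 1 in one place: 4-phenyl-1,3-thiazol-2-yl in place of 4-acetamidophenyl on an amide-type nitrogen. Going by the values given here, no step between two measured compounds is available to gauge this change, and the shared core with its long fluorinated chain and hydroxamic acid is kept in both. The expected step from compound 1 to compound 3 in this assay is a number no higher from compound 1 to compound 3 (the limit leaves the size open), that is, no change beyond the scatter in either direction. Compound 3 is therefore expected to give about 50000 nM, with a range from 15000 nM to 200000 nM, and most likely only a limit will be reported again.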

Compound 3, inhibition constant: > 50000 nM
Compound 3: only a limit was reported; the forecaster's own chance of this, stated with the estimate: 80%; the middle value lies on the limit itself.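

No step from compound 1 to compound 3 can be read, since both values are limits and not numbers: the limit of > 50000 nM in this assay, at which 3 of the 3 values shown sit.

The compounds shown leave open how strongly any of them inhibits the enzyme, and whether 4-phenyl-1,3-thiazol-2-yl in place of 4-acetamidophenyl changes the inhibition at all.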